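The compounds below may be only part of what the source reports. "The series", "measured", "known", "first", "only" and "open" are said of these compounds alone.

Three compounds have been measured in an assay for inhibition of 15-hydroxyprostaglandin dehydrogenase [NAD(+)] (Homo sapiens), read by fluorescence, with a stated time of 15 min, in the presence of a further agent that is not named here; a lower number here means a stronger inhibitor, a higher number a weaker inhibitor:

Compound 1 `Nc1c([S+]([O-])CCCCl)sc2nc(-c3cccs3)cc(-c3ccccc3)c12` gives 4 nM.
Compound 2 `CCCC[S+]([O-])c1sc2nc(-c3nccs3)cc(-c3ccc(C(=O)N(C)C)cc3)c2c1N` gives 5.9 nM.
Compound 3 `CCC[S+]([O-])c1sc2nc(-c3cccs3)cc(C(=O)OCC)c2c1N` gives 2 nM.

Among these three, compound 2 has the highest number in this assay. Its value and that of compound 1 lie within the usual scatter of each other, so nothing separates the two. Compound 3 gives a clearly lower number, beyond the scatter, and so is the stronger inhibitor of that pair.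

The next compound, compound 4 `CCCC[S+]([O-])c1sc2nc(-c3nccs3)cc(-c3ccc(C(C)(C)O)cc3)c2c1N`, keeps the whole core of compound 2 and changes one group on its six-membered aromatic ring of carbon only: 1-hydroxy-1-methylethyl in place of dimethylcarbamoyl on an aromatic carbon. Within the data shown here, no pair of measured compounds here differs in only this way, so no measured step shows what such a swap does. Both groups are small and carry one hydrogen-bond acceptor, and the rest of the molecule is unchanged. The step expected from this change, a 1.0-fold higher number from compound 2 to compound 4 (0.01 log units; within the scatter), is none beyond the scatter in this assay. Compound 4 is therefore estimated at about 6 nM, with a likely range from 2.5 nM to 15 nM.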

Compound 4, half-maximal inhibitory concentration: 3.6 nM
Compound 4: the middle estimate sits 1.7-fold (0.22 log units) above what was measured, within the range that was stated.
By their numbers in this assay, from the lowest: compounds 3, 4, 1 and 2 (each within the scatter of the next, the first and the last beyond it).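

In this assay, among these compounds, putting 1-hydroxy-1-methylethyl in place of dimethylcarbamoyl on the aromatic carbon para to a large group gives a 1.6-fold lower number from compound 2 to compound 4 (0.21 log units; within the scatter), the first one-place comparison here, and it leaves the two compounds indistinguishable. The group that leaves carries no hydrogen-bond donor and the group that enters carries one, yet this difference, together with one heavy atom fewer, produces no separation beyond the scatter at this position. Nothing shown explains why the two groups read alike.

The compounds shown compare just these two groups at this place, so it stays open whether a carboxylic acid, an aminomethyl group or a plain hydrogen would also stay within the scatter of compound 2. Also open, from the compounds shown here alone, is whether the same swap would read alike on the core of compound 1.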